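Arylpiperazine variation and alpha-1B binding

This account rests on a few compounds, and the source may have more. Where it says the series, first, only, none or still open, it means among the compounds named here.

Compound 1 `COCC1=C(C(=O)OC)C(c2cc(F)c(F)cc2F)N(C(=O)NCCCN2CCN(c3ccccc3C(N)=O)CC2)C(=O)N1`: 130 nM
Compound 2 `CCOc1ccccc1N1CCN(CCCNC(=O)N2C(=O)NC(C)=C(C(=O)OC)C2c2ccc(F)c(F)c2)CC1`: 8.8 nM

In an assay on liver for binding affinity to Alpha-1B adrenergic receptor (Homo sapiens), using microsomes (a lower number here means a stronger inhibitor, a higher number a weaker inhibitor), compound 2 gives the lower of the two numbers; compound 1 gives a higher value, and the gap between them lies beyond the scatter. Compound 3 `COC(=O)C1=C(C)NC(=O)N(C(=O)NCCCN2CCN(c3cccc(Cl)c3)CC2)C1c1ccc(F)c(F)c1` has not yet been measured in this assay. It differs from compound 2 by 3-chlorophenyl in place of 2-ethoxyphenyl on an amine nitrogen in a ring. Within the data shown here, no pair of measured compounds isolates this change, so the size of the step is uncertain. Compound 3 is expected to bind somewhat more weakly than compound 2, with a step of a 4.5-fold higher number from compound 2 to compound 3 (0.66 log units; beyond the scatter) in this assay. The estimate for compound 3 is 40 nM, ranging from 10 nM to 160 nM.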

Compound 3, inhibition constant: 8.4 nM
Beside the measured number, compound 3's estimate is 4.8-fold (0.68 log units) above it; measured number below the stated range.
By their numbers in this assay, from the lowest: compounds 3 and 2 (each within the scatter of the next); then compound 1.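

In this assay, 3-chlorophenyl in place of 2-ethoxyphenyl on the amine nitrogen in the ring gives a 1.0-fold lower number from compound 2 to compound 3 (0.02 log units; within the scatter) and leaves binding unchanged. This position therefore accepts either group, and the oxygen of the 2-ethoxyphenyl group, with its hydrogen-bond acceptor, is not needed for binding at this level in this series. Nothing shown explains why the two groups match. As far as these compounds go, whether a plain phenyl, a 2-chlorophenyl or a 3-ethoxyphenyl on the same nitrogen would also match remains open. The part played by the substituent and the part played by its place on the ring therefore cannot be separated.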